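This account rests on a few compounds, and the source may have more. Where it says the series, first, only, none or still open, it means among the compounds named here.

Measured so far:
Compound 1, `Cc1ccccc1Cc1cnc(N)nc1N`, gives 29500 nM in an assay for inhibition of Dihydrofolate reductase (Gallus gallus); on this read-out lower numbers stand for stronger inhibition and higher numbers for weaker inhibition.
Compound 2, `C=CCOc1ccccc1Cc1cnc(N)nc1N`, gives 21400 nM in this assay.

Within the data shown here, of these two numbers compound 2 holds the lowest, yet its only neighbour, compound 1, sits close by: the step of a 1.4-fold lower number from compound 1 to compound 2 (0.14 log units; within the scatter) lies within the scatter, so the two compounds cannot be told apart on this evidence.

Compound 3, `CCOc1ccccc1Cc1cnc(N)nc1N`, has not yet been measured. It differs from compound 2 in one place: methyl in place of vinyl on a saturated chain carbon bound to an oxygen on an aromatic ring. The chain on the oxygen becomes shorter and loses its double bond; everything else stays the same.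

Among the measured compounds shown here, only one measured step exists, and it concerns a different change, allyloxy in place of methyl on an aromatic carbon, which gave a 1.4-fold lower number from compound 1 to compound 2 (0.14 log units; within the scatter). That step shows that altering this side group moved the number little, but it does not test the chain itself. Nothing points to a shift in either direction. For compound 3 the expected step is a 1.0-fold higher number from compound 2 to compound 3 (0.01 log units; within the scatter), none beyond the scatter. Compound 3 is therefore estimated at 22000 nM, with a likely range from 9000 nM to 55000 nM.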

Compound 3, inhibition constant: 24500 nM
Compound 3: the middle estimate sits 1.1-fold (0.05 log units) below what was measured; measured number inside the range.
By their numbers in this assay, from the lowest: compounds 2, 3 and 1 (each within the scatter of the next).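

Replacing allyloxy with ethoxy tests the chain on the oxygen directly: in this assay it gives a 1.1-fold higher number from compound 2 to compound 3 (0.06 log units; within the scatter), so losing the double bond and shortening the chain leave compound 2 and compound 3 indistinguishable. Among these compounds, the comparison with the methyl group gives a 1.2-fold lower number from compound 1 to compound 3 (0.08 log units; within the scatter), which means that methyl, ethoxy and allyloxy on this aromatic carbon now all lie within the scatter of one another, and this three-way agreement is more than the single earlier step could show. No independent evidence accompanies these numbers to account for the lack of separation.

From the compounds shown here alone, the three compounds cover only methyl, ethoxy and allyloxy, so it remains open whether a longer chain, an amine or a carboxylic acid in this place would stay within the scatter or shift the number clearly in either direction. Going by these compounds, it is also open whether these groups would still be indistinguishable if another part of the shared core were changed.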